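Acyl group swap on the trifluoromethyl-bearing core

The source may report more compounds than this note shows. Statements on the series, on what has been measured and on what is new or still open speak of the compounds shown alone.

Measured so far in an assay on HEK293 cells for displacement of a labelled ligand from Melanocortin receptor 4 (Homo sapiens); on this read-out higher numbers stand for weaker inhibition and lower numbers for stronger inhibition:
compound 1 `CC(C)C[C@H](N)c1ccccc1N1CCN(C(=O)[C@H](C)Cc2ccc(Cl)cc2F)CC1`: 67 nM
compound 2 `CC(C)C[C@H](N)c1cc(C(F)(F)F)ccc1N1CCN(C(=O)COc2cccc(Cl)c2Cl)CC1`: 2500 nM
compound 3 `Cc1ccc(N2CCN(C(=O)[C@H](C)Cc3ccc(Cl)cc3F)CC2)c([C@@H](N)CC(C)C)c1`: 20 nM

Compound 2 gives the highest number of the three in this assay; compound 1 and compound 3 both sit well below it, beyond the scatter. Compound 4 `Cc1cc(Cl)ccc1CC(C)C(=O)N1CCN(c2ccc(C(F)(F)F)cc2[C@@H](N)CC(C)C)CC1` is not yet measured. It differs from compound 2 in one place: 1-(4-chloro-2-methylbenzyl)ethyl in place of (2,3-dichlorophenoxy)methyl on a carbonyl carbon.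

Among the compounds with values here, the only step recorded between measured compounds, a 3.4-fold lower number from compound 1 to compound 3 (0.53 log units; beyond the scatter), concerns a change on an aromatic carbon, not the acyl group, and so bears on the present change only indirectly. Compound 1 and compound 2 differ in two places, so their values are only a hint: the compound carrying a 1-(4-chloro-2-fluorobenzyl)ethyl acyl group, compound 1, gives 67 nM, while compound 2 with the (2,3-dichlorophenoxy)methyl group gives 2500 nM. The group entering in compound 4 is close in shape to the acyl group of compound 1 and compound 3, so a large drop in the number is expected, an estimated 21-fold lower number from compound 2 to compound 4 (1.32 log units; beyond the scatter). Compound 4 is therefore expected to come in at about 120 nM, between 30 nM and 500 nM.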

Compound 4, inhibition constant: 38 nM
Compound 4: middle estimate off by 3.2-fold (0.50 log units), on the high side; the measured number falls inside the stated range.
By their numbers in this assay, from the lowest: compounds 3, 4 and 1 (each within the scatter of the next, the first and the last beyond it); then compound 2.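

On the carbonyl carbon of the shared core, 1-(4-chloro-2-methylbenzyl)ethyl in place of (2,3-dichlorophenoxy)methyl gives, in this assay, a 66-fold lower number from compound 2 to compound 4 (1.82 log units; beyond the scatter). Within the data shown here, this is the first reading of the acyl group in which only one place changes, and it shows that this position responds strongly to this exchange, where the earlier compounds offered only a hint from a pair differing in two places. The two groups are close in their count of heavy atoms, and nothing at hand gives a measured reason for the size of the step.

Which part of the exchange carries the step remains open, whether the oxygen of the leaving group, the branching of the chain or the ring substituents. Also open, as far as these compounds go, is how a longer chain or a pyridine ring would fare on this carbonyl carbon.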